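Ester series: pyrrolyl in place of ethyl on the core

This account rests on a few compounds, and the source may have more. Where it says the series, first, only, none or still open, it means among the compounds named here.

Within the data shown here, compound 2 `CCc1nc(C(=O)OC)nn1-c1ccc(F)cc1` is the only member with a number in a functional assay on Jurkat cells (Homo sapiens) for inhibition, read by MTT assay, with a stated time of 72 h; on this read-out higher numbers stand for weaker inhibition of growth and lower numbers for stronger inhibition of growth; there compound 2 gives 11000 nM. Compound 1 `COC(=O)c1nc(C)n(-c2ccc(OC)cc2)n1` sits at a limit of this assay and gives only > 100000 nM, as noted in the limit of > 100000 nM in this assay, at which 1 of the 2 values shown sits. Among the measured compounds shown here, no step between measured compounds is available to guide the change to compound 3 `COC(=O)c1nc(-c2ccc[nH]2)n(-c2ccc(F)cc2)n1`, which carries 1H-pyrrol-2-yl in place of ethyl on an aromatic carbon. The step from compound 2 to compound 3 is expected to be a modest gain, somewhat beyond the scatter, a 2.2-fold lower number from compound 2 to compound 3 (0.34 log units; beyond the scatter). Compound 3 is estimated at 5000 nM, with a range from 1500 nM to 20000 nM.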

Compound 3, concentration for 50% growth inhibition: 9010 nM
The estimate for compound 3 lay 1.8-fold (0.26 log units) below the measured number; the range from low to high includes it.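

In this assay, 1H-pyrrol-2-yl in place of ethyl on this aromatic carbon gives a 1.2-fold lower number from compound 2 to compound 3 (0.09 log units; within the scatter). For compound 2 and compound 3, adding the five-membered aromatic ring and its hydrogen-bond donor at this position therefore leaves growth inhibition unchanged within the scatter. No measurement at hand bears on why this change has so little effect.

Still open, on these data alone, is whether a 1-methyl-1H-pyrrol-2-yl group at this position would behave alike, which would separate the ring from the hydrogen-bond donor. A carboxylic acid in place of the methoxycarbonyl group is also untested among the compounds shown.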